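This account rests on a few compounds, and the source may have more. Where it says the series, first, only, none or still open, it means among the compounds named here.

Working notes on the series. Compound 1 `Nc1nn(CC(=O)NCCO)c2nc(-c3ccccc3)cc(C(F)(F)F)c12` gives 78200 nM in a functional assay on MCF7 cells (Homo sapiens) for cytotoxicity, read by MTT assay, with a stated time of 24 h; on this read-out lower numbers stand for stronger inhibition and higher numbers for weaker inhibition. Among the measured compounds shown here, compound 2 `Nc1nn(CC(=O)NCc2ccco2)c2nc(-c3ccccc3)cc(C(F)(F)F)c12` gives 5000 nM in this assay, the lower of the two numbers measured so far, and the single step recorded, a 16-fold lower number from compound 1 to compound 2 (1.19 log units; beyond the scatter), is large. Compound 3 `Nc1nn(CC(=O)N2CCCC2)c2nc(-c3ccccc3)cc(C(F)(F)F)c12` is not yet measured. It differs from compound 2 by pyrrolidin-1-yl in place of ((furan-2-yl)methyl)amino on a carbonyl carbon. For the measured compounds named here, only the step from compound 1 to compound 2 bears on this change, and only indirectly: it shows that the group on the amide nitrogen matters, and that the furan-2-yl bearing chain gave the lower number. Going by the values given here, compound 3 gives up that group entirely, so a somewhat higher number than compound 2 is expected in this assay, of roughly the size a 3.0-fold higher number from compound 2 to compound 3 (0.48 log units; beyond the scatter), though the data give no direct step for a ring-closed amide nitrogen. For compound 3 the estimate is 15000 nM, with a range from 4000 nM to 60000 nM.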

Compound 3, half-maximal inhibitory concentration: 15900 nM
The estimate for compound 3 lay 1.1-fold (0.03 log units) below the measured number, and the stated range covers the measured number.
By their numbers in this assay, from the lowest: compound 2; then compound 3; then compound 1.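

In this assay, the amide nitrogen need not carry a hydrogen for activity to remain: closing it into pyrrolidin-1-yl gives a 4.9-fold lower number from compound 1 to compound 3 (0.69 log units; beyond the scatter), yet this change still falls short of the ((furan-2-yl)methyl)amino group, with a 3.2-fold higher number from compound 2 to compound 3 (0.50 log units; beyond the scatter). On the carbonyl carbon, the order therefore runs ((furan-2-yl)methyl)amino, then pyrrolidin-1-yl, then (2-hydroxyethyl)amino, so a group without the amide hydrogen sits inside the range set by two groups that have it. No measurement available here bears on why these groups rank in this order.

The change from compound 2 to compound 3 removes the furan-2-yl ring and the amide hydrogen together, so their separate contributions stay unresolved. A benzylamino group, or a piperidin-1-yl or morpholin-4-yl ring on the same carbonyl carbon, would help separate them.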